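The compounds below may be only part of what the source reports. "The series", "measured", "known", "first", "only" and "open" are said of these compounds alone.

Compound 1 `FC(F)(F)c1ccc([B-]2(c3ccc(C(F)(F)F)cc3)[NH2+]CCO2)cc1` gives 13700 nM in an assay on HEK293 cells for inhibition of transient receptor potential cation channel subfamily V member 6 (Homo sapiens), read by FLIPR, with a stated time of 5 min; a higher number here means a weaker inhibitor, a lower number a stronger inhibitor.
Compound 2 `Fc1ccc([B-]2(c3ccc(F)cc3)[NH2+]CCO2)cc1` gives 14200 nM in this assay.
Compound 3 `Fc1ccc([B-]2(c3ccccc3)[NH2+]CCO2)cc1` gives 33600 nM in this assay.

Compound 3 stands at the highest number of the three, so it is the weakest inhibitor measured here; its nearest neighbour is compound 2, and the gap to compound 1 is of about the same size. Among the compounds with values here, the one step recorded between two compounds that differ in a single place is the move from compound 2 to compound 3, a 2.4-fold higher number from compound 2 to compound 3 (0.37 log units; beyond the scatter), where the fluoro on one aromatic ring is replaced by hydrogen. Compounds 1 and 2 differ by trifluoromethyl against fluoro and their two values lie close together.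

Compound 4 `Brc1ccc([B-]2(c3ccccc3)[NH2+]CCO2)cc1` is not yet measured. It differs from compound 3 by bromo in place of fluoro on an aromatic carbon. Within the data shown here, no measured step swaps one halogen for another, so only a weak expectation can be drawn: since a fluoro at this place helped over hydrogen, a bromo is expected to keep or slightly lower the number. The expected step from compound 3 to compound 4 is a 1.5-fold lower number from compound 3 to compound 4 (0.18 log units; within the scatter), and compound 4 is estimated at 22000 nM, between 8000 nM and 55000 nM.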

Compound 4, half-maximal inhibitory concentration: 9800 nM
Beside the measured number, compound 4's estimate is 2.2-fold (0.35 log units) above it; measured number inside the range.
By their numbers in this assay, from the lowest: compounds 4, 1 and 2 (each within the scatter of the next); then compound 3.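

Changing one halogen for another at this place, on an aromatic carbon para to a large group, moves the result in this assay: bromo in place of fluoro gives a 3.4-fold lower number from compound 3 to compound 4 (0.54 log units; beyond the scatter). The earlier compounds shown here showed only that fluoro differs from hydrogen on such a ring, whereas this step shows that the identity of the halogen matters too, with a change that lies beyond the usual scatter. Nothing measured here accounts for why bromo gives the lower number.

On these data alone, it remains open whether chloro or iodo at this same place would follow bromo, or whether a methoxy group or an amine would do as well. Also unanswered is whether a second bromo on the plain ring of compound 4 would lower the number further.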